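The source may hold more compounds than are shown below. What is called first, only, known or untested is meant among the compounds shown, and "the series" means these compounds.

In a functional assay on HepG2 cells (Homo sapiens) for antiproliferative activity, read by MTT assay, with a stated time of 48 h (on this read-out lower numbers stand for stronger inhibition and higher numbers for weaker inhibition), compound 1 `COc1ccccc1NC(=O)Nc1cccc(CNc2nccnc2Cl)c1` gives 13700 nM. Compound 2 `O=C(Nc1cccc(CNc2nccnc2Cl)c1)NC1CCCCC1` shares its core but gives > 40000 nM. That value is a limit of the assay and not a number, so compound 2 has no exact position on the scale.

Compound 3 `O=C(Nc1cccc(CNc2nccnc2Cl)c1)Nc1ccc(Cl)c(Cl)c1` has 3,4-dichlorophenyl in place of cyclohexyl on an amide-type nitrogen. An aromatic ring thus returns to that nitrogen, as in compound 1, although it is a different one. Going by the values given here, only one measured step bears on this change: an at least 2.9-fold higher number from compound 1 to compound 2 (0.46 log units; beyond the scatter). That step lies beyond the scatter and runs the opposite way, from an aromatic ring to cyclohexyl. A move back towards lower numbers is therefore expected, but this single pair is thin support, and the new ring carries different substituents. The expected step is an at least 4.0-fold lower number from compound 2 to compound 3 (0.60 log units; beyond the scatter). For compound 3, the estimated value in this assay is 10000 nM, with an expected range of 3000 nM to 32000 nM.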

Compound 3, half-maximal inhibitory concentration: 6170 nM
Beside the measured number, compound 3's estimate is 1.6-fold (0.21 log units) above it; the measured number falls inside the stated range.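

Setting 3,4-dichlorophenyl in place of cyclohexyl on the amide-type nitrogen gives an at least 6.4-fold lower number from compound 2 to compound 3 (0.81 log units; beyond the scatter) in this assay. Compound 2 stands at a limit of the assay and not at a number: the limit of > 40000 nM in this assay, at which 1 of the 3 values shown sits.

The aromatic rings also differ from each other, since 3,4-dichlorophenyl in place of 2-methoxyphenyl gives a 2.2-fold lower number from compound 1 to compound 3 (0.35 log units; beyond the scatter); among these three compounds, the two with an aromatic ring on this nitrogen give measured numbers, and the choice of ring shifts the number modestly.

Open, from the compounds shown here alone, is how much of the lower number of compound 3 belongs to the aromatic ring itself and how much to its chlorine atoms, a split that a plain phenyl on this nitrogen would help to make. Also open, going by these compounds, is whether a pyridyl ring or a benzyl group here would keep the number as low.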